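Exchanging the aryl group on a shared core

The compounds below may be only part of what the source reports. "The series", "measured", "known", "first", "only" and "open" are said of these compounds alone.

For the measured compounds named here, compound 2 `COc1ccc(-c2cn(C(=O)NCCCCc3ccccc3)c(=O)o2)cc1` is one of two compounds measured in an assay on isolated protein for inhibition of acid ceramidase (Homo sapiens), read by LC-MS, with a stated time of 1 h (a higher number here means a weaker inhibitor, a lower number a stronger inhibitor), where compound 2 gives 400 nM. Going by the values given here, its only neighbour is compound 1 `O=C(NCCCCc1ccccc1)n1cc(-c2ccc(Cl)cc2)oc1=O`, which in this assay gives 83 nM; compound 2 thus stands at the weaker end of the two numbers, and the step of a 4.8-fold higher number from compound 1 to compound 2 (0.68 log units; beyond the scatter) is the only measured change on this core. The unmeasured compound 3 `O=C(NCCCCc1ccccc1)n1cc(-c2ccccn2)oc1=O` differs from compound 2 in one place: pyridin-2-yl in place of 4-methoxyphenyl on an aromatic carbon. The measured step from compound 1 to compound 2 bears on this only indirectly, since it exchanged two substituents on the same aryl ring rather than the ring itself, yet it shows that a change of the group on the core moves this assay by a modest amount. Among the compounds with values here, no measured step tells the direction for an aromatic ring bearing a nitrogen in place of the methoxyphenyl. The step of a 1.6-fold lower number from compound 2 to compound 3 (0.20 log units; within the scatter) is therefore expected to stay within the scatter. In this assay compound 3 is estimated at 250 nM, with a range from 70 nM to 900 nM.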

Compound 3, half-maximal inhibitory concentration: 25 nM
Estimate against measurement, compound 3: 10-fold (1.00 log units) above; the measured number lies below the stated range.
By their numbers in this assay, from the lowest: compound 3; then compound 1; then compound 2.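

In this assay, exchanging the whole aryl ring at this aromatic carbon, next to the ring oxygen, gives a large change, a 16-fold lower number from compound 2 to compound 3 (1.20 log units; beyond the scatter), whereas the earlier exchange of substituents on the ring gave only a modest one, a 4.8-fold higher number from compound 1 to compound 2 (0.68 log units; beyond the scatter). The pyridin-2-yl group also improves on the 4-chlorophenyl group, a 3.3-fold lower number from compound 1 to compound 3 (0.52 log units; beyond the scatter), so compound 3 is the strongest inhibitor of the three, and a substituted phenyl ring is not needed at this position for a low number. Nothing shown here explains why the ring with a nitrogen gives the lowest number.

The compounds leave open how much of the step belongs to the ring nitrogen itself, since a plain phenyl group would be needed to separate it from the loss of the ring substituent, and whether pyridin-3-yl or pyridin-4-yl would behave like pyridin-2-yl. On these data alone, all three compounds also carry the same chain ending in a phenyl ring, so it remains open whether the order of these aryl groups would hold with a shorter chain or with an amine at its end.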